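This account rests on a few compounds, and the source may have more. Where it says the series, first, only, none or still open, it means among the compounds named here.

Measured so far:

compound 1, `CC(C)CCn1ccc(OCc2ccccc2)c(C#N)c1=O` — in a functional assay on CHO cells for positive allosteric modulation of metabotropic glutamate receptor 2 (Homo sapiens), with a stated time of 30 min (a lower number here means a smaller maximal response, a higher number a larger maximal response), compound 1 gives 173%
compound 2, `CC(C)CCn1ccc(N(C)Cc2ccccc2)c(C#N)c1=O` — in this assay compound 2 gives 249%
compound 3, `CC(C)CCn1ccc(N2CCC(c3ccccc3)CC2)c(C#N)c1=O` — in this assay compound 3 gives 268%

Among these three numbers compound 3 stands highest. The nearest to it is compound 2, whose number lies lower by a gap beyond the usual scatter; the furthest is compound 1, whose number lies much lower, also beyond the scatter. All three share the same core and differ only in the group attached to it.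

Compound 4, `CC(C)CCn1ccc(N2CCCCC2)c(C#N)c1=O`, has not yet been measured in this assay. It differs from compound 3 in one place: hydrogen in place of phenyl on a saturated ring carbon. The phenyl leaves and a hydrogen enters on a saturated ring carbon of the six-membered non-aromatic ring with one nitrogen.

Among the compounds with values here, no single-change step between measured compounds is available, so no step size can be computed directly. Compound 2 and compound 3 both carry a phenyl and both sit well above compound 1, which carries a benzyl ether. Taking the phenyl away entirely in compound 4 is therefore expected to lower the maximal response, by a moderate step beyond the scatter, a number 53 percentage points lower from compound 3 to compound 4 (beyond the scatter). For compound 4 the estimated value in this assay is 215%, with a range from 150% to 265%.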

Compound 4, largest response reached (Emax), in percent of the reference or control that the assay uses: 185%
Compound 4: the middle estimate sits 30 percentage points above what was measured; the range from low to high includes it.
By their numbers in this assay, from the lowest: compound 1; then compound 4; then compound 2; then compound 3.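

Within the data shown here, replacing the phenyl with hydrogen on the saturated ring carbon gives a number 83 percentage points lower from compound 3 to compound 4 (beyond the scatter) in this assay, and this is the first single-change step, so the phenyl at this place can now be tied directly to a higher maximal response. The phenyl does not account for the whole response, however, since compound 4 still gives 185% without it. Nothing among the available data explains why this change has so large an effect.

The compounds shown leave open whether a methyl or a hydroxyl on the same saturated ring carbon would restore part of the response, or whether a full phenyl is needed. They also leave open how a fluorine or a methoxy group on that phenyl would shift the number in this assay.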